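Methoxy for Amino on a Nucleoside Core

This account rests on a few compounds, and the source may have more. Where it says the series, first, only, none or still open, it means among the compounds named here.

Measured compounds:
- compound 1 `Nc1nc(N)c2c(-c3ccsc3)cn([C@@H]3O[C@H](CO)[C@@H](O)[C@H]3O)c2n1`: > 20000 nM
- compound 2 `CN(C)c1ncnc2c1c(-c1ccsc1)cn2[C@@H]1O[C@H](CO)[C@@H](O)[C@H]1O`: > 20000 nM
- compound 3 `O=c1[nH]cnc2c1c(-c1cccs1)cn2[C@@H]1O[C@H](CO)[C@@H](O)[C@H]1O`: > 20000 nM

Of the compounds shown here, three have been tested in a functional assay on HepG2 cells (Homo sapiens) for antiproliferative activity, read by XTT assay, with a stated time of 72 h; a lower number here means a stronger inhibitor, a higher number a weaker inhibitor. In this assay compound 1 gives > 20000 nM, a limit of the assay rather than a number. For compound 2 this assay likewise reports only the limit > 20000 nM. Compound 3 also stops at the limit > 20000 nM. Compound 1 therefore stands at the same limit as every other compound shown, and no ranking among them is possible: the limit of > 20000 nM in this assay, at which 3 of the 3 values shown sit.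

Compound 4 `COc1nc(N)nc2c1c(-c1ccsc1)cn2[C@@H]1O[C@H](CO)[C@@H](O)[C@H]1O` has not yet been measured. It differs from compound 1 in one place: methoxy in place of amino on an aromatic carbon. For the measured compounds named here, no step between two measured compounds with a number exists here, so the expected size of the change from compound 1 to compound 4 in this assay cannot be anchored; given that compound 1 sits at > 20000 nM, no movement beyond the scatter is expected, and the most likely outcome is again a limit. Compound 4 is estimated at 30000 nM, within 10000 nM to 100000 nM, which is expected to mean a step that the limit leaves unreadable from compound 1 to compound 4.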

Compound 4, half-maximal inhibitory concentration: > 20000 nM
Compound 4 ended at the assay's limit (the forecaster's own chance of this, stated with the estimate: 85%); the middle value is on the limit's open side.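

Compound 1 and compound 4 both stop at a limit of the assay and not at a number in this assay, so no step can be read for methoxy in place of amino: the limit of > 20000 nM in this assay, at which 4 of the 4 values shown sit.

The compounds shown leave open whether any change to the shared core gives a readable value, and how these compounds rank against one another.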